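A few compounds are considered here, and "the series" means these few. Any claim that something is new, unique, unknown or untested is made for them only; others in the source may bear on it.

Measured so far:
compound 1, `O=C(CSc1nc(Nc2ccccc2)c2ccccc2n1)Nc1cccc(Br)c1`: 10100 nM
compound 2, `O=C(CSc1nc(Nc2ccccc2)c2ccccc2n1)Nc1ccc(Br)cc1`: 10600 nM

In a functional assay on NCI-H1975 cells (Homo sapiens) for inhibition, read by MTT assay, with a stated time of 72 h (on this read-out higher numbers stand for weaker inhibition and lower numbers for stronger inhibition), compound 2 gives 10600 nM, the highest of the two numbers, with compound 1 nearest. Among the measured compounds shown here, the only step measured, from compound 1 to compound 2, was a 1.0-fold higher number from compound 1 to compound 2 (0.02 log units; within the scatter): moving the bromine on that ring changed nothing beyond scatter. Compound 3, `O=C(CSc1nc(Nc2ccccc2)c2ccccc2n1)Nc1ccc(Cl)cc1Cl`, carries 2,4-dichlorophenyl in place of 4-bromophenyl on an amide-type nitrogen. For the measured compounds named here, that measured step is the only one bearing on this change, and it points to no shift beyond the scatter, so the expected step is a 1.1-fold lower number from compound 2 to compound 3 (0.03 log units; within the scatter). Compound 3 is therefore estimated at 10000 nM in this assay, expected between 4500 nM and 25000 nM.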

Compound 3, half-maximal inhibitory concentration: 8410 nM
Compound 3: the middle estimate sits 1.2-fold (0.08 log units) above what was measured; low and high end bracket the measured number.
By their numbers in this assay, from the lowest: compounds 3, 1 and 2 (each within the scatter of the next).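

Replacing the bromine with two chlorines at this position, as 2,4-dichlorophenyl on the amide-type nitrogen, leaves this assay essentially unmoved (a 1.3-fold lower number from compound 2 to compound 3 (0.10 log units; within the scatter)) and (a 1.2-fold lower number from compound 1 to compound 3 (0.08 log units; within the scatter)). The earlier pair covered only a moved bromine, whereas these steps show that a different halogen and a second halogen on the ring also stay within the scatter. No available evidence offers an explanation for this result.

Still open, as far as these compounds go, is whether an amine or a carboxylic acid on this ring would shift the number beyond the scatter. The same question applies to replacing the ring with a longer chain.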